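The source may report more compounds than this note shows. Statements on the series, on what has been measured and on what is new or still open speak of the compounds shown alone.

Measured compounds:
Compound 1, `O=C(N/N=C/c1ccc(F)cc1)c1cccnc1Nc1cccc(C(F)(F)F)c1`, gives 41.3%.
Compound 2, `O=C(N/N=C/c1ccc(O)cc1)c1cccnc1Nc1cccc(C(F)(F)F)c1`, gives 59.5%.
Compound 3, `CN(C)c1ccc(/C=N/NC(=O)c2cccnc2Nc2cccc(C(F)(F)F)c2)cc1`, gives 39.5%.

All three were tested in a functional assay on the whole organism (strain Wistar) for inhibition, with Rattus norvegicus as the target, read by paw edema, with a stated time of 3 h, at a dose of 10 mg/kg by the intraperitoneal route; on this read-out higher numbers stand for more inhibition at the one dose given (going by the name of the read-out) and lower numbers for less inhibition. Compound 1 stands second highest of the three numbers, though its reading and that of compound 3 lie within the usual scatter of each other, so no order between them can be claimed. Compound 2 sits clearly above it: a number 18.2 percentage points higher from compound 1 to compound 2 (beyond the scatter). The step to compound 3, a number 1.8 percentage points lower from compound 1 to compound 3 (within the scatter), is no change at all in practice.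

Compound 4, `O=C(N/N=C/c1cccnc1)c1cccnc1Nc1cccc(C(F)(F)F)c1`, has not yet been measured. It differs from compound 1 in one place: pyridin-3-yl in place of 4-fluorophenyl on a carbon with a double bond to nitrogen. Here the whole ring attached to the carbon with a double bond to nitrogen is exchanged, not just a substituent on it. Within the data shown here, no measured step makes that kind of exchange, so none bears on it directly. The two steps that start from compound 1 only vary the group on the phenyl ring, and they gave a modest rise in one case and nothing beyond scatter in the other. With no closer guide, the change is expected to produce little movement: the estimated step is a number 3.7 percentage points higher from compound 1 to compound 4 (within the scatter). Compound 4 is therefore expected to give about 45%, within a range of 25% to 65%.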

Compound 4, a percentage reported as inhibition, in the whole organism at one dose (the size of the read-out at that dose, not a potency): 52.4%
Compound 4: the middle estimate sits 7.4 percentage points below what was measured; the measured number falls inside the stated range.
By their numbers in this assay, from the lowest: compounds 3 and 1 (each within the scatter of the next); then compounds 4 and 2 (each within the scatter of the next).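

Exchanging the whole ring on the carbon with a double bond to nitrogen turns out to matter in this assay: pyridin-3-yl in place of 4-fluorophenyl gives (a number 11.1 percentage points higher from compound 1 to compound 4 (beyond the scatter)), and pyridin-3-yl in place of 4-(dimethylamino)phenyl gives (a number 12.9 percentage points higher from compound 3 to compound 4 (beyond the scatter)). Until now only the hydroxy group had lifted the reading above that of compound 1, but the comparison with the hydroxy compound gives (a number 7.1 percentage points lower from compound 2 to compound 4 (within the scatter)), so a ring with a nitrogen in it and no substituent cannot be told apart from 4-hydroxyphenyl here, and this position accepts more than a change of group on a phenyl ring. Nothing measured here explains why these ring changes shift the reading.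

Whether the nitrogen's place in the ring counts stays open, since pyridin-2-yl and pyridin-4-yl do not appear among these compounds, and neither does a saturated ring such as piperidin-4-yl. A carboxylic acid or a primary amine on the phenyl ring would also show whether the rise seen with hydroxy extends to other groups.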